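Amide aryl swap on a phthalazine-piperazine acetamide

This account rests on a few compounds, and the source may have more. Where it says the series, first, only, none or still open, it means among the compounds named here.

Compound 1: `O=C(CN1CCN(c2nnc(Cc3ccncc3)c3ccccc23)CC1)Nc1ccc(F)c(F)c1` — 2320 nM
Compound 2: `O=C(CN1CCN(c2nnc(Cc3ccccc3)c3ccccc23)CC1)Nc1ccc(F)c(F)c1` — 9510 nM

Of the compounds shown here, two have been measured in a functional assay on HT-29 cells (Homo sapiens) for cytotoxicity, read by MTT assay, with a stated time of 72 h; on this read-out higher numbers stand for weaker inhibition and lower numbers for stronger inhibition. Compound 1 has the lowest of the two numbers; its nearest neighbour is compound 2, and the step of a 4.1-fold higher number from compound 1 to compound 2 (0.61 log units; beyond the scatter) separates them. Compound 3, `Cc1ccc(F)cc1NC(=O)CN1CCN(c2nnc(Cc3ccncc3)c3ccccc23)CC1`, has not been measured. It differs from compound 1 at the amide-type nitrogen whose other neighbour is the carbonyl carbon: 5-fluoro-2-methylphenyl in place of 3,4-difluorophenyl on an amide-type nitrogen. Among the measured compounds shown here, the one measured step concerns a different position, the saturated chain carbon bound to an aromatic carbon, so no measured step bears directly on this change. Without a comparable precedent, no shift beyond the scatter is expected in this assay, and the range around the estimate is kept wide. Compound 3 is therefore estimated at 3000 nM, within 1000 nM to 10000 nM, an expected step of a 1.3-fold higher number from compound 1 to compound 3 (0.11 log units; within the scatter).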

Compound 3, half-maximal inhibitory concentration: 470 nM
Estimate against measurement, compound 3: 6.4-fold (0.81 log units) above; the whole stated range lies above it.
By their numbers in this assay, from the lowest: compound 3; then compound 1; then compound 2.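

Among the compounds shown here, compound 3 shows that the aryl group on the amide-type nitrogen is a position that responds in this assay: with the pyridin-4-yl group unchanged, 5-fluoro-2-methylphenyl in place of 3,4-difluorophenyl gives a 4.9-fold lower number from compound 1 to compound 3 (0.69 log units; beyond the scatter) and so outranks the earlier compounds. Both groups have the same count of heavy atoms and the same single six-membered aromatic ring of carbon only, yet the number still moves beyond the scatter, something the earlier step at the saturated chain carbon could not show. Nothing in hand accounts for this shift.

On these data alone, whether the methyl or the altered fluorine pattern carries the step remains open, as does whether it would hold with phenyl in place of pyridin-4-yl. A 2-methylphenyl or 2-methoxyphenyl group on the same nitrogen would help separate these possibilities.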